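The source may hold more compounds than are shown below. What is called first, only, known or untested is meant among the compounds shown, and "the series" means these compounds.

For the measured compounds named here, in an ADME assay on microsomes from liver (Rattus norvegicus) for metabolic stability, read by LC-MS, using NADPH, with a stated time of 60 min, tested at 0.1 uM (on this read-out higher numbers stand for a more stable compound and lower numbers for a less stable compound), compound 1 (`Fc1ccc(Nc2cc3[nH]c(Nc4cc(N5CCNCC5)ccn4)nc3cn2)cc1C(F)(F)F`) gives 73% and stands highest of the two numbers so far, with compound 2 (`C[C@H]1CN(c2ccc(Nc3nc4cnc(Nc5cccc(C(F)(F)F)c5)cc4[nH]3)nc2)CCN1`) at 53% lower by a gap beyond the usual scatter. Compound 3 (`C[C@@H]1CN(C(=O)c2ccnc(Nc3nc4cnc(Nc5ccc(F)c(C(F)(F)F)c5)cc4[nH]3)c2)C[C@H](C)O1`) keeps the core of compound 1 but carries (2,6-dimethylmorpholin-4-yl)carbonyl in place of piperazin-1-yl on an aromatic carbon. Going by the values given here, no pair of measured compounds shows this change, so any forecast is loose. In this assay a moderate fall beyond the scatter is expected, with a number 23 percentage points lower from compound 1 to compound 3 (beyond the scatter) as the estimated step. Compound 3 is estimated at 50% with a likely range from 22% to 78% around it.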

Compound 3, percent of the compound remaining: 65%
Compound 3: middle estimate off by 15 percentage points, on the low side; the range from low to high includes it.
By their numbers in this assay, from the lowest: compound 2; then compounds 3 and 1 (each within the scatter of the next).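

In this assay, placing (2,6-dimethylmorpholin-4-yl)carbonyl where piperazin-1-yl stood gives a number 8 percentage points lower from compound 1 to compound 3 (within the scatter). So this place, opposite the ring nitrogen, can hold a larger group with a carbonyl and two defined stereocentres, and the percent of compound remaining stays within the usual scatter. Nothing at hand gives a reason for this result. Still open, as far as these compounds go, is whether the carbonyl or the two methyl groups matter more for this read-out. From the compounds shown here alone, how a plain morpholin-4-yl group or a carboxylic acid would behave at this place also remains unknown.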